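The source may hold more compounds than are shown below. What is called first, only, known or untested is meant among the compounds shown, and "the series" means these compounds.

Measured so far in a functional assay on HepG2 cells (Homo sapiens) for inhibition, read by MTT assay, with a stated time of 72 h; a lower number here means a stronger inhibitor, a higher number a weaker inhibitor 
- compound 1 `COc1cc(O)c(CC=C(C)C)c(O)c1C(=O)/C=C/c1ccc(O)c(O)c1` gives 15200 nM 
- compound 2 `COc1ccccc1/C=C/C(=O)c1c(OC)cc(O)c(CC=C(C)C)c1O` gives 14600 nM 
- compound 3 `COc1cc(O)c(CC=C(C)C)c(O)c1C(=O)/C=C/c1ccc([N+](=O)[O-])cc1` gives 12400 nM 

Compound 3 stands level with the other two: a 1.2-fold lower number from compound 1 to compound 3 (0.09 log units; within the scatter) and a 1.2-fold lower number from compound 2 to compound 3 (0.07 log units; within the scatter) are both small. Next is compound 4 `COc1cc(O)c(CC=C(C)C)c(O)c1C(=O)/C=C/c1cccc([N+](=O)[O-])c1` with 3-nitrophenyl in place of 4-nitrophenyl on a double-bonded chain carbon bound to a double-bonded chain carbon, counted as 3-nitrophenyl in place of 4-nitrophenyl on a double-bonded chain carbon bound to a double-bonded chain carbon in full. The same place has taken other groups: a 1.0-fold lower number from compound 1 to compound 2 (0.02 log units; within the scatter) joins those two steps, and none of the three leaves the scatter. Among the measured compounds shown here, no measured step moves the nitro group itself, so direct precedent is lacking. In this assay no step beyond the scatter is expected, in either direction. The estimated step is a 1.0-fold higher number from compound 3 to compound 4 (0.02 log units; within the scatter) in size. Compound 4 is estimated at 13000 nM and expected to fall from 7000 nM to 24000 nM across its range.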

Compound 4, half-maximal inhibitory concentration: 16600 nM
Compound 4: the middle estimate sits 1.3-fold (0.11 log units) below what was measured, within the range that was stated.
By their numbers in this assay, from the lowest: compounds 3, 2, 1 and 4 (each within the scatter of the next).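

In this assay, among the compounds shown here, 3-nitrophenyl in place of 4-nitrophenyl is the first measured move of the nitro group itself, and it stays within the scatter (a 1.3-fold higher number from compound 3 to compound 4 (0.13 log units; within the scatter)). The steps to the other two groups also stay within it (a 1.1-fold higher number from compound 2 to compound 4 (0.06 log units; within the scatter); a 1.1-fold higher number from compound 1 to compound 4 (0.04 log units; within the scatter)), so all four aryl groups on a double-bonded chain carbon bound to a double-bonded chain carbon read alike. No measured evidence bears on why this place tolerates these changes.

Going by these compounds, whether an amine, a carboxylic acid or a longer chain at this place would leave the scatter stays open. So does the effect of any change elsewhere on the shared core.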